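This account rests on a few compounds, and the source may have more. Where it says the series, first, only, none or still open, it means among the compounds named here.

In an ADME assay on HEK293 cells (Homo sapiens) for cytotoxicity, read by resazurin assay, with a stated time of 48 h (on this read-out higher numbers stand for lower toxicity in this test and lower numbers for higher toxicity in this test), compound 2 `COc1ccc(Cl)cc1S(=O)(=O)Nc1ccc(-c2nc3ccccc3o2)cc1` gives 75000 nM, the highest of the three numbers, though within the scatter of compound 3 `Cc1cccc(S(=O)(=O)Nc2ccc3oc(-c4ccccc4)nc3c2)c1` at 69000 nM and of compound 1 `Cc1ccccc1S(=O)(=O)Nc1ccc2oc(-c3ccccc3)nc2c1` at 57000 nM. Among the measured compounds shown here, the one step between measured compounds, a 1.2-fold higher number from compound 1 to compound 3 (0.08 log units; within the scatter), changed nothing beyond the scatter. Compound 4 `O=S(=O)(Nc1ccc(-c2nc3ccccc3o2)cc1)c1ccc(F)cc1` differs from compound 2 by 4-fluorophenyl in place of 5-chloro-2-methoxyphenyl on a sulfonyl sulfur. For the measured compounds named here, no measured step covers this exchange, and the only step there is, from compound 1 to compound 3, swapped one aryl group for another without effect. A step of a 1.1-fold lower number from compound 2 to compound 4 (0.03 log units; within the scatter) is therefore expected, none beyond the scatter. Compound 4 is estimated to give 70000 nM in this assay, with a range from 35000 nM to 140000 nM.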

Compound 4, half-maximal cytotoxic concentration: > 100000 nM
Compound 4 gave a limit, no number (the forecaster's own chance of this, stated with the estimate: 15%); at least 1.4-fold (0.15 log units) between middle value and limit.
By their numbers in this assay, from the lowest: compounds 1, 3 and 2 (each within the scatter of the next). At a limit, above all of these: compound 4.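

In this assay, the exchange on a sulfonyl sulfur gives an at least 1.3-fold higher number from compound 2 to compound 4 (0.12 log units; that floor lies within the scatter). Compound 4 yields only a limit of the assay, not a number: the limit of > 100000 nM in this assay, at which 1 of the 4 values shown sits. This change is thus the only one shown that ends at a limit, so its true size is unknown and it cannot be said to lie beyond the scatter. Going by these compounds, it remains open whether an amine or a carboxylic acid on the phenyl ring at this sulfonyl sulfur would give a number or a limit. On these data alone, whether 4-fluorophenyl would also reach the limit on the core of compound 1 stays open too.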